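The source may report more compounds than this note shows. Statements on the series, on what has been measured and on what is new or still open speak of the compounds shown alone.

Three compounds built on a shared core were examined in an ADME assay on HEp-2 cells (Homo sapiens) for cytotoxicity, read by CCK-8 assay, with a stated time of 6 days; a lower number here means that less compound is tolerated, a higher number that more compound is tolerated. Compound 1 `O=c1n(Cc2nc3ccc(Cl)cn3c2CCCCO)c2cnccc2n1C1CC1` carries a chloro group on its core, and in this assay compound 1 reaches a limit of the assay, > 100000 nM. Compound 2 `O=c1n(Cc2nc3ccc(C(F)(F)F)cn3c2CCCCO)c2cnccc2n1C1CC1` carries a trifluoromethyl group in the same place, and in this assay compound 2 likewise sits at a limit, > 100000 nM. Compound 3 `O=c1n(Cc2nc3cc(C(F)(F)F)ccn3c2CCCCO)c2cnccc2n1C1CC1` has the same atoms as compound 2, joined differently; the difference between the two cores is not broken down here. In this assay compound 3 also gives a limit, > 100000 nM.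

The change from compound 2 to compound 1 is chloro in place of trifluoromethyl on an aromatic carbon; its step, a step that the two limits leave unreadable from compound 2 to compound 1, cannot be read, due to the limit of > 100000 nM in this assay, at which 3 of the 3 values shown sit.

Compound 4 `O=c1n(Cc2nc3cc(Cl)ccn3c2CCCCO)c2cnccc2n1C1CC1` is not yet measured. It differs from compound 3 by chloro in place of trifluoromethyl on an aromatic carbon, the same kind of change, here opposite the ring nitrogen rather than two atoms from it. The step from compound 3 to compound 4 is therefore expected to be small, a step that the limit leaves unreadable from compound 3 to compound 4. Compound 4 is expected to give 150000 nM, between 60000 nM and 400000 nM.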

Compound 4, half-maximal cytotoxic concentration: > 100000 nM
Compound 4 ended at the assay's limit; the forecaster's own chance of this, stated with the estimate: 85%; the middle value is on the limit's open side.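

No new step can be read between compound 3 and compound 4 in this assay, due to the shared limit: the limit of > 100000 nM in this assay, at which 4 of the 4 values shown sit.

The compounds shown leave open where the half-maximal cytotoxic concentration of any of them actually lies, and so whether swapping trifluoromethyl for chloro changes it at either place on the core.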